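The source may hold more compounds than are shown below. What is called first, only, known or untested is meant among the compounds shown, and "the series" means these compounds.

Measured so far in a functional assay on SK-MEL-5 cells (Homo sapiens) for inhibition, read by sulforhodamine B assay, with a stated time of 48 h, tested at 10 uM; a higher number here means more inhibition at the concentration tested (going by the name of the read-out), a lower number less inhibition:
compound 1, `O=Cc1ccc(-c2cn3ccnc3c(-c3ccc4ncn(C5CCCCC5)c4c3)n2)cc1`: 56.5%
compound 2, `O=Cc1ccc(-c2cn3ccnc3c(-c3ccc4ncn(Cc5ccccc5)c4c3)n2)cc1`: 56.5%
compound 3, `c1cn2cc(-c3ccc4c(c3)ncn4C3CCCCC3)nc(-c3ccc4ncn(C5CCCCC5)c4c3)c2n1`: 36.8%

Compounds 1 and 2 share one core and differ in a single place, (benzyl in place of cyclohexyl on an aromatic nitrogen). That exchange gives no change at the digits printed from compound 1 to compound 2 (within the scatter). Compound 3 carries a different core; how that core differs from the core of compound 1 is not broken down here. In this assay compound 3 stands lowest of the three values, beyond the scatter from compound 1 and from compound 2 alike.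

Compound 4, `c1ccc(Cn2cnc3ccc(-c4nc(-c5ccc6c(c5)ncn6C5CCCCC5)cn5ccnc45)cc32)cc1`, has not yet been measured in this assay. Going by the values given here, it arises from compound 3 by benzyl in place of cyclohexyl on an aromatic nitrogen, the same change as the one between compound 1 and compound 2, and the place is described in the same words for both pairs. Among the compounds with values here, the only measured step of this change is no change at the digits printed from compound 1 to compound 2 (within the scatter), which lies within the scatter. On that basis the expected step here is a number 0.2 percentage points higher from compound 3 to compound 4 (within the scatter), matching the earlier one. Since this rests on a single step measured on another core, the range is kept wide. Compound 4 is therefore estimated at 37%, between 22% and 52%.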

Compound 4, a percentage reported as inhibition, at one concentration (the size of the read-out at that concentration, not a potency): -84%
The estimate for compound 4 lay 121 percentage points above the measured number; the whole stated range lies above it.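

In this assay, benzyl in place of cyclohexyl on an aromatic nitrogen gives a number 120.8 percentage points lower from compound 3 to compound 4 (beyond the scatter), so the outcome of this change in this series depends on the core that carries it. Going by these compounds alone, the step on the core of compound 1 is therefore no guide to the step on the core of compound 3: the same change on two cores in this assay, no change at the digits printed (within the scatter) from compound 1 to compound 2 and a number 120.8 percentage points lower (beyond the scatter) from compound 3 to compound 4, 120.8 percentage points apart, beyond the scatter of two such steps With only one pair on each core, this does not show which difference between the cores goes with the gap, nor whether the negative reading of compound 4, -84%, would hold on repetition.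

The compounds shown leave open whether the large step belongs to benzyl in particular or would also appear with other groups on that nitrogen, such as a longer alkyl chain or a chain ending in an amine or a carboxylic acid. They also leave open what happens when the remaining cyclohexyl of compound 4 is exchanged for benzyl.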